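Compound 1 loses its carbonyl

The source may hold more compounds than are shown below. What is called first, only, known or untested is meant among the compounds shown, and "the series" means these compounds.

Of the compounds shown here, three with a shared core have been tested in an ADME assay on cells (Homo sapiens) for cytotoxicity, read by resazurin assay, with a stated time of 5 days; on this read-out lower numbers stand for higher toxicity in this test and higher numbers for lower toxicity in this test. Going by the values given here, compound 1 (`COc1ccc(-c2nc(CC(=O)c3cccc(Cl)c3)nc3ccsc23)cn1`) gives 30000 nM, the only actual number among the three. Compound 2 (`COc1ccc(-c2nc(S(=O)(=O)c3cccc(Cl)c3)nc3ccsc23)cn1`) reaches only a limit in this assay, > 50000 nM. Compound 3 (`COc1ccc(-c2nc(C(C)S(=O)(=O)c3cccc(Cl)c3)nc3ccsc23)cn1`) likewise reaches only a limit, > 50000 nM. These two limits give no step size, so compound 1 has no measured neighbour against which a change can be sized.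

Compound 4 (`COc1ccc(-c2nc(CCc3cccc(Cl)c3)nc3ccsc23)cn1`) has not yet been measured. It carries 3-chlorobenzyl in place of (3-chlorophenyl)carbonyl on a saturated chain carbon bound to an aromatic carbon. Among the compounds with values here, no measured pair isolates this change. With compound 1 at 30000 nM as the sole numerical anchor, no shift beyond the usual scatter is expected in this assay, and neither direction can be favoured. A result that ends at a limit, as for compound 2 and compound 3, would remain possible. The expected change, no change at the digits printed from compound 1 to compound 4 (within the scatter), is therefore small. For compound 4 the estimated value is 30000 nM, with an expected range of 12000 nM to 70000 nM.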

Compound 4, half-maximal cytotoxic concentration: > 50000 nM
Compound 4: a limit, no number; the forecaster's own chance of this, stated with the estimate: 30%; middle value at least 1.6-fold (0.22 log units) away from the limit.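

With 3-chlorobenzyl in place of (3-chlorophenyl)carbonyl on a saturated chain carbon bound to an aromatic carbon, this assay shows an at least 1.6-fold higher number from compound 1 to compound 4 (0.22 log units; that floor lies within the scatter). Going by these compounds alone, this is the first step measured at this position, and it gives no sign that losing the carbonyl brings the number down, the direction that would stand for higher toxicity in this test. Compound 4 gives > 50000 nM, which is a limit of the assay and not a number, so the full size of the step cannot be read, because the read-out stops short for most of the compounds shown: the limit of > 50000 nM in this assay, at which 3 of the 4 values shown sit.

What the compounds shown leave open is whether any group at this place can bring the number down again, for instance an amine or a carboxylic acid on the chain, or a longer chain in place of the one in compound 4. A change that gives a real number would be needed to size such steps, since a further result at the limit could not be ordered against compound 4.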